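Aryl variation on the aromatic nitrogen of the core

The source may report more compounds than this note shows. Statements on the series, on what has been measured and on what is new or still open speak of the compounds shown alone.

Measured in a functional assay on HT-29 cells (Homo sapiens) for antiproliferative activity, read by MTT assay, with a stated time of 72 h; a lower number here means a stronger inhibitor, a higher number a weaker inhibitor:
compound 1 `O=C(Nc1ccc(Oc2ccnc3[nH]ccc23)cc1)c1cc2cccnc2n(-c2ccc(F)cc2)c1=O` gives 160 nM
compound 2 `O=C(Nc1ccc(Oc2ccnc3[nH]ccc23)cc1)c1cc2cccnc2n(-c2ccc(Cl)cc2)c1=O` gives 280 nM
compound 3 `O=C(Nc1ccc(Oc2ccnc3[nH]ccc23)cc1)c1cc2cccnc2n(-c2ccc(Br)cc2F)c1=O` gives 2360 nM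

Compound 3 carries the highest number of the three: a 15-fold higher number from compound 1 to compound 3 (1.17 log units; beyond the scatter) and an 8.4-fold higher number from compound 2 to compound 3 (0.93 log units; beyond the scatter) both lie beyond the scatter, whereas a 1.8-fold higher number from compound 1 to compound 2 (0.24 log units; within the scatter) does not. Compound 4 `O=C(Nc1ccc(Oc2ccnc3[nH]ccc23)cc1)c1cc2cccnc2n(-c2ccc(C(F)(F)F)cc2Cl)c1=O` differs from compound 3 by 2-chloro-4-(trifluoromethyl)phenyl in place of 4-bromo-2-fluorophenyl on an aromatic nitrogen. Going by the values given here, no measured step covers this change directly. The two steps that reach compound 3 show that leaving 4-fluorophenyl or 4-chlorophenyl for 4-bromo-2-fluorophenyl raised the number sharply, and compound 4 keeps a group of 1 heavy atom in the same place while enlarging the rest. The number for compound 4 is therefore expected to stay high, with a 1.5-fold higher number from compound 3 to compound 4 (0.17 log units; within the scatter) as the estimated step in this assay. Compound 4 is estimated at 3500 nM, within 1200 nM to 10000 nM.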

Compound 4, half-maximal inhibitory concentration: 2160 nM
For compound 4 the middle estimate is 1.6-fold (0.21 log units) above the measured one; the measured number falls inside the stated range.
By their numbers in this assay, from the lowest: compounds 1 and 2 (each within the scatter of the next); then compounds 4 and 3 (each within the scatter of the next).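

In this assay, a 1.1-fold lower number from compound 3 to compound 4 (0.04 log units; within the scatter) shows that 2-chloro-4-(trifluoromethyl)phenyl and 4-bromo-2-fluorophenyl cannot be told apart on this aromatic nitrogen, although the entering group has 11 heavy atoms against 8. The high number thus recurs with a different pair of substituents, with a 7.7-fold higher number from compound 2 to compound 4 (0.89 log units; beyond the scatter) and a 14-fold higher number from compound 1 to compound 4 (1.13 log units; beyond the scatter) as the steps from the 4-chlorophenyl and 4-fluorophenyl groups. Nothing available explains these steps. As far as these compounds go, compound 3 and compound 4 each differ from compound 1 at more than one aryl substituent, so the contribution of each stays open. From the compounds shown here alone, whether an amine or a carboxylic acid on this aryl group would bring the number down also stays open.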